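The source may report more compounds than this note shows. Statements on the series, on what has been measured and on what is new or still open speak of the compounds shown alone.

Compounds measured so far:
- compound 1 `CCCCC1([C@H](O)/C=C/[C@H]2COC(=O)N2CCSc2nc(C(=O)O)cs2)CCC1`: 73 nM
- compound 2 `CC(C)(CCCCF)[C@H](O)/C=C/[C@H]1COC(=O)N1CCSc1nc(C(=O)O)cs1`: 1220 nM
- compound 3 `O=C(O)c1csc(SCCN2C(=O)OC[C@@H]2/C=C/[C@@H](O)C2(CCc3ccccc3)CCC2)n1`: 465 nM

All three were run in an assay on isolated protein for agonist activity at prostaglandin E2 receptor EP4 subtype (Homo sapiens); on this read-out higher numbers stand for an effect only at larger amounts of compound and lower numbers for an effect already at smaller amounts. Compound 1 holds the lowest number of the three; the nearest is compound 3, reached by a 6.4-fold higher number from compound 1 to compound 3 (0.80 log units; beyond the scatter), and the furthest is compound 2, reached by a 17-fold higher number from compound 1 to compound 2 (1.22 log units; beyond the scatter).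

Compound 4 `COCCCC1([C@H](O)/C=C/[C@H]2COC(=O)N2CCSc2nc(C(=O)O)cs2)CCC1` is not yet measured. Relative to compound 1 the change is methoxy in place of methyl on a saturated chain carbon, three bonds along the chain from a saturated ring carbon. Neither measured step matches this change: the step to compound 3 alters the same chain, but by a bulkier, ring-bearing replacement, and the step to compound 2 opens the ring and moves a fluorine into the chain. What both steps show is that any departure from the butyl chain of compound 1 has so far cost activity in this assay, the smaller departure by the modest amount and the larger departure by the large amount. The change to compound 4 is the smallest of the three, so a rise of no more than modest size is expected, with a value within the scatter of compound 1 also possible.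

The expected step is a 2.2-fold higher number from compound 1 to compound 4 (0.34 log units; beyond the scatter). For compound 4 the estimate in this assay is 160 nM, with a range from 50 nM to 500 nM.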

Compound 4, half-maximal effective concentration: 705 nM
For compound 4 the middle estimate is 4.4-fold (0.64 log units) below the measured one; the measured number lies above the stated range.
By their numbers in this assay, from the lowest: compound 1; then compounds 3, 4 and 2 (each within the scatter of the next, the first and the last beyond it).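

In this assay, the change from butyl to 3-methoxypropyl on the cyclobutyl-bearing core of compound 1 gives a 9.7-fold higher number from compound 1 to compound 4 (0.98 log units; beyond the scatter), showing that this chain position is sensitive even to methoxy in place of methyl, with no ring added and the ring of compound 1 kept. Among the compounds shown, the cost does not follow the extent of the replacement: the 3-methoxypropyl chain cannot be separated from the phenyl-bearing chain (a 1.5-fold higher number from compound 3 to compound 4 (0.18 log units; within the scatter)) or from the opened 5-fluoro-1,1-dimethylpentyl group (a 1.7-fold lower number from compound 2 to compound 4 (0.24 log units; within the scatter)), so all three replacements fall in one band above compound 1. Nothing available explains the loss at this position.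

Still open, on these data alone, is whether a hydroxyl, an amine or a fluorine in place of the methyl at this place on the chain would cost as much, and whether a pentyl chain would match compound 1 at 73 nM or not. A 2-ethoxyethyl chain would also test whether the effect follows the presence of the oxygen or the place it occupies along the chain.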